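The source may hold more compounds than are shown below. What is called first, only, known or untested is meant among the compounds shown, and "the series" means these compounds.

Measured so far in a functional assay for inhibition, with Homo sapiens as the target; a lower number here means a stronger inhibitor, a higher number a weaker inhibitor:
compound 1 `CCCc1nc(C)c2cnn(CC)c(=O)n12`: > 48000 nM
compound 2 `CCCc1nc(C)c2cnn(C)c(=O)n12`: 20000 nM

The value of compound 1 is a limit of this assay, not a number; compound 1 sits at the limit of > 48000 nM in this assay, at which 1 of the 2 values shown sits. Going by the values given here, the only measured step, an at least 2.4-fold lower number from compound 1 to compound 2 (0.38 log units; beyond the scatter), concerns a different place from the change considered here, so no measured step bears on it directly. Compound 3 `CCn1ncc2c(C)nc(C(C)C)n2c1=O` differs from compound 1 by isopropyl in place of propyl on an aromatic carbon. Among the compounds with values here, with no comparable step, no change beyond the scatter is expected. Compound 3 is therefore estimated at 50000 nM, ranging from 20000 nM to 150000 nM. The expected step is a step that the limit leaves unreadable from compound 1 to compound 3, and a limit is again likely.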

Compound 3, half-maximal inhibitory concentration: > 48000 nM
Compound 3: only a limit was reported; the forecaster's own chance of this, stated with the estimate: 60%; the middle value does not contradict the limit.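

No step can be read between compound 1 and compound 3, because each gives only a limit: the limit of > 48000 nM in this assay, at which 2 of the 3 values shown sit.

Going by these compounds, whether isopropyl in place of propyl on an aromatic carbon changes inhibition at all remains open.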